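Aryl variation at the fused ring of the sulfonamide series

The source may hold more compounds than are shown below. What is called first, only, known or untested is meant among the compounds shown, and "the series" means these compounds.

Measured so far:
- compound 1 `COc1ccc(S(=O)(=O)N2CCc3cccc(-c4cccnc4)c32)cc1` gives 89.6 nM in a functional assay on NCI-H460 cells (Homo sapiens) for inhibition, with a stated time of 72 h; on this read-out lower numbers stand for stronger inhibition and higher numbers for weaker inhibition
- compound 2 `COc1ccc(S(=O)(=O)N2CCc3cccc(-c4c(F)c(F)c(F)c(F)c4F)c32)cc1` gives 4760 nM
- compound 3 `COc1ccc(S(=O)(=O)N2CCc3cccc(-c4ccc(F)c(F)c4)c32)cc1` gives 46 nM

Compound 3 shows the lowest number of the three in this assay. Its nearest neighbour is compound 1, and that pair sits within the scatter: a 1.9-fold lower number from compound 1 to compound 3 (0.29 log units; within the scatter). Among the measured compounds shown here, compound 2 stands far from compound 3, beyond the scatter, but no single-site step connects the two; their values only show that the pentafluorophenyl compound gives a much higher number than the 3,4-difluorophenyl one.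

Compound 4 `COc1ccc(S(=O)(=O)N2CCc3cccc(-c4ccccc4)c32)cc1` is not yet measured. It differs from compound 3 as follows: phenyl in place of 3,4-difluorophenyl on an aromatic carbon.

For the measured compounds named here, no measured step changes fluorine count on the aryl ring alone, so nothing bears directly on this change. Going by the values given here, the one measured step, from pyridin-3-yl to 3,4-difluorophenyl, stayed within the scatter, and the two carbocyclic aryl compounds differ widely. For compound 4 the expected step is a 1.7-fold higher number from compound 3 to compound 4 (0.24 log units; within the scatter), a number near that of compound 3 and not clearly beyond the scatter. The estimate for compound 4 in this assay is 80 nM, with a range from 25 nM to 300 nM.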

Compound 4, half-maximal inhibitory concentration: 213 nM
Beside the measured number, compound 4's estimate is 2.7-fold (0.43 log units) below it; measured number inside the range.
By their numbers in this assay, from the lowest: compounds 3 and 1 (each within the scatter of the next); then compound 4; then compound 2.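

Notes on the aryl position: in this assay the change from 3,4-difluorophenyl to phenyl gives a 4.6-fold higher number from compound 3 to compound 4 (0.67 log units; beyond the scatter), the first step at this position to lie beyond the scatter, so the two fluorines are not neutral here. Phenyl also separates from pyridin-3-yl, with a 2.4-fold higher number from compound 1 to compound 4 (0.38 log units; beyond the scatter), which places compound 4 apart from both compound 1 and compound 3 even though those two remain within the scatter of each other. Nothing available explains either step.

Still open, from the compounds shown here alone, is whether a single fluorine, as in 3-fluorophenyl or 4-fluorophenyl, is enough to account for the step from phenyl. Also open, going by these compounds, is how other substituted rings, such as 3,4-dichlorophenyl or 4-methoxyphenyl, would read at this position, and how many fluorines separate compound 3 from the much higher number of pentafluorophenyl compound 2.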